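Chloroacetamide to chloro-heteroaryl amides on the shared core

The source may report more compounds than this note shows. Statements on the series, on what has been measured and on what is new or still open speak of the compounds shown alone.

Compound 1 `O=C(CCl)Nc1cccc(-c2nc3ccccc3s2)c1` gives 1700 nM in an ADME assay on Raji cells (Homo sapiens) for inhibition, with a stated time of 72 h (on this read-out higher numbers stand for an effect only at larger amounts of compound and lower numbers for an effect already at smaller amounts), the lowest of the two numbers measured here. Compound 2 `O=C(Nc1cccc(-c2nc3ccccc3s2)c1)c1cnccc1Cl` gives 12000 nM in the same read-out. For compound 3 `O=C(Nc1cccc(-c2nc3ccccc3s2)c1)c1cccnc1Cl` only a limit is recorded, > 25000 nM, so its number is not known (the limit of > 25000 nM in this assay, at which 1 of the 3 values shown sits). Both replacements of the chloromethyl group on the carbonyl carbon by a chloro-substituted six-membered aromatic ring moved the read-out upward: a 7.1-fold higher number from compound 1 to compound 2 (0.85 log units; beyond the scatter) and an at least 14-fold higher number from compound 1 to compound 3 (1.16 log units; beyond the scatter); between the two aromatic variants the shift was an at least 2.0-fold higher number from compound 2 to compound 3 (0.31 log units; beyond the scatter).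

Compound 4 `O=C(Nc1cccc(-c2nc3ccccc3s2)c1)c1cnc(Cl)s1` is not yet measured. It differs from compound 1 by 2-chloro-1,3-thiazol-5-yl in place of chloromethyl on a carbonyl carbon. The two steps that bear on this change are those from compound 1 to compound 2 and from compound 1 to compound 3, both to higher numbers, one modest and one large. A chloro-substituted five-membered aromatic ring entering in the same place is therefore expected to give a higher number than compound 1 as well, of modest to large size, and compound 4 is estimated at 10000 nM, within 3000 nM to 25000 nM, which corresponds to an expected step of a 5.9-fold higher number from compound 1 to compound 4 (0.77 log units; beyond the scatter).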

Compound 4, half-maximal effective concentration: > 25000 nM
Compound 4 gave a limit, no number; the forecaster's own chance of this, stated with the estimate: 25%; middle value at least 2.5-fold (0.39 log units) from the limit.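

A chloro-substituted five-membered aromatic ring, 2-chloro-1,3-thiazol-5-yl, on the carbonyl carbon also moves the read-out in this assay upward from chloromethyl, with an at least 14-fold higher number from compound 1 to compound 4 (1.16 log units; beyond the scatter), so among the compounds shown this direction is no longer confined to the two chloropyridinyl rings and has no exception. The same ring also stands apart from 4-chloropyridin-3-yl, with an at least 2.0-fold higher number from compound 2 to compound 4 (0.31 log units; beyond the scatter), which leaves compound 2 as the only one of the three aromatic amides with a measured number. Compound 3 and compound 4 both rest at a limit, and the step between them cannot be read: the limit of > 25000 nM in this assay, at which 2 of the 4 values shown sit.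

Going by these compounds, it remains open whether the upward move follows the aromatic ring itself or the chlorine on it, which an unsubstituted pyridin-3-yl ring on the same carbonyl carbon would help to separate. On these data alone, it is equally open how much of the lower number of compound 1 depends on the chlorine of its chloromethyl group, and a plain methyl group or a longer chain such as 2-chloroethyl in that place would bear on this.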